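Notes on the step from compound 2 to compound 3

This account rests on a few compounds, and the source may have more. Where it says the series, first, only, none or still open, it means among the compounds named here.

The set rests on the shared core of compound 1 `CC(=O)c1cccc(-c2ccc(C(=O)N(Cc3cccc(OCCCCCC(=O)O)c3)C(C)C)cc2)c1` and is read in an ADME assay on Raji cells (Homo sapiens) for cytotoxicity, read by CellTiter-Glo and resazurin assay, with a stated time of 72 h; a lower number here means that less compound is needed, a higher number that more compound is needed for the effect. In this assay compound 1 gives > 26000 nM, a limit rather than a number. Compound 2 `CC(C)N(Cc1cccc(OCCCCCC(=O)O)c1)C(=O)c1ccc(-c2cccc(O)c2)cc1` carries a hydroxy in place of the acetyl on an aromatic carbon. In this assay compound 2 gives > 26000 nM, again only a limit. The step that the two limits leave unreadable from compound 1 to compound 2 is therefore not readable. Both values sit at the limit of > 26000 nM in this assay, at which 2 of the 2 values shown sit, so compound 2 stands at that limit with no number of its own.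

Compound 3 `CC(C)N(Cc1cccc(OCCCCCC(=O)O)c1)C(=O)c1ccc(-c2cccc(S(C)(=O)=O)c2)cc1` differs from compound 2 by methylsulfonyl in place of hydroxy on an aromatic carbon. Among the compounds with values here, no measured step reads on this change, and the only step in the set, acetyl to hydroxy, is hidden by the two limits. No step beyond the scatter is therefore expected. In this assay compound 3 is expected to give 40000 nM, within 15000 nM to 150000 nM, most likely as a limit once more. The expected step is a step that the limit leaves unreadable from compound 2 to compound 3.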

Compound 3, half-maximal effective concentration: > 26000 nM
Compound 3: no number, only a limit; the forecaster's own chance of this, stated with the estimate: 85%; the middle value lies beyond the limit too.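

No step can be read among compound 1, compound 2 and compound 3 in this assay, each of which gives only a limit: the limit of > 26000 nM in this assay, at which 3 of the 3 values shown sit.

Left open is whether acetyl, hydroxy and methylsulfonyl differ at all in this assay: none of the compounds shown has a number of its own.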